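The source may report more compounds than this note shows. Statements on the series, on what has been measured and on what is new or still open speak of the compounds shown alone.

Compounds measured in an assay on isolated protein for binding affinity to melanin-concentrating hormone receptor 1 (Homo sapiens); a lower number here means a stronger inhibitor, a higher number a weaker inhibitor:
compound 1, `Cc1ccc(CN2CCC(=Cc3ccc(C(=O)N[C@H](C)c4ccc(Br)cc4)cc3)CC2)c(C)c1`, gives 105 nM;
compound 2, `CC[C@@H](NC(=O)c1ccc(CC2CCN(Cc3ccc4cncnc4c3)CC2)cc1)c1ccc(I)cc1`, gives 30 nM.

Compound 2 stands at the lower of the two numbers in this assay, and compound 1 lies beyond the scatter from it. The two differ in several places at once, so no single change is read from that pair.

Compound 3, `CC[C@@H](NC(=O)c1ccc(CC2CCN(Cc3ccc4nccnc4c3)CC2)cc1)c1ccc(I)cc1`, differs from compound 2 in one place: quinoxalin-6-yl in place of quinazolin-7-yl on a saturated chain carbon bound to an amine nitrogen in a ring. The two have the same atoms, joined differently. Going by the values given here, no measured pair shows a change of this kind, so there is no step to lean on.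

The expectation for compound 3 is a step of a 1.2-fold higher number from compound 2 to compound 3 (0.07 log units; within the scatter) in this assay, that is, nothing beyond the scatter. Going by these compounds, compound 3 is estimated at 35 nM, with a range from 12 nM to 100 nM, the width reflecting that the change is untested here.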

Compound 3, inhibition constant: 40 nM
For compound 3 the middle estimate is 1.1-fold (0.06 log units) below the measured one; the measured number falls inside the stated range.
By their numbers in this assay, from the lowest: compounds 2 and 3 (each within the scatter of the next); then compound 1.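

In this assay, going by these compounds alone, the exchange of quinazolin-7-yl for quinoxalin-6-yl gives a 1.3-fold higher number from compound 2 to compound 3 (0.12 log units; within the scatter) and so supplies the first single-place comparison. On a saturated chain carbon bound to an amine nitrogen in a ring, these two isomeric bicyclic groups cannot be told apart in this assay, so the arrangement of the two ring nitrogens in this pair does not separate the compounds. No supporting evidence bears on this result, and the step itself gives no explanation for it.

Going by these compounds, whether any ring nitrogen is needed at this place remains open, as the two groups compared both carry two, and naphthalen-2-yl, with carbon only, or quinolin-6-yl, with a single ring nitrogen, would address that. Also open, on these data alone, is whether a monocyclic group such as pyridin-3-yl could replace the bicyclic group here.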